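A few compounds are considered here, and "the series" means these few. Any claim that something is new, unique, unknown or untested is made for them only; others in the source may bear on it.

Measured so far in an assay on microsomes from liver for inhibition of sterol O-acyltransferase 1 (Rattus norvegicus); on this read-out lower numbers stand for stronger inhibition and higher numbers for weaker inhibition:
compound 1 `CCCCCCCOc1cc(-c2ccccc2)c(-c2ccccc2)nn1` gives 58000 nM
compound 2 `CCCCCCCCCOc1cc(-c2ccccc2)c(-c2ccccc2)nn1` gives 180000 nM
compound 3 `CCCCCCCSc1cc(-c2ccccc2)c(-c2ccccc2)nn1` gives 76000 nM

Compound 3 differs from compound 1 by heptylsulfanyl in place of heptyloxy on an aromatic carbon; the step is a 1.3-fold higher number from compound 1 to compound 3 (0.12 log units; within the scatter), so the two cores sit close together on this assay. Compound 2 differs from compound 1 by ethyl in place of hydrogen on a saturated chain carbon, seven bonds along the chain from an oxygen on an aromatic ring, and the chain extension costs: a 3.1-fold higher number from compound 1 to compound 2 (0.49 log units; beyond the scatter).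

Compound 4 `CCCCCCCCCSc1cc(-c2ccccc2)c(-c2ccccc2)nn1` is not yet measured. It differs from compound 3 by ethyl in place of hydrogen on a saturated chain carbon, seven bonds along the chain from a sulfur. Within the data shown here, this is the same kind of change as the one from compound 1 to compound 2, not the same: there the carbon is seven bonds along the chain from an oxygen on an aromatic ring, here seven bonds along the chain from a sulfur.

Among the measured compounds shown here, with only one earlier example of the extension, the expectation is that the step from compound 3 to compound 4 is of similar size, a 3.0-fold higher number from compound 3 to compound 4 (0.48 log units; beyond the scatter), beside a 3.1-fold higher number from compound 1 to compound 2 (0.49 log units; beyond the scatter); this rests on that single step and on compound 3 standing at 76000 nM, close to compound 1. Compound 4 is therefore estimated at 230000 nM, with a range from 100000 nM to 520000 nM.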

Compound 4, half-maximal inhibitory concentration: 116000 nM
Beside the measured number, compound 4's estimate is 2.0-fold (0.30 log units) above it; low and high end bracket the measured number.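

In this assay, the ethyl extension on the sulfur-linked chain gives a 1.5-fold higher number from compound 3 to compound 4 (0.18 log units; within the scatter), while the same extension on the oxygen-linked chain gave a step beyond the scatter. Set side by side, the two steps cannot be told apart: the same change on two cores in this assay, a 3.1-fold higher number (0.49 log units; beyond the scatter) from compound 1 to compound 2 and a 1.5-fold higher number (0.18 log units; within the scatter) from compound 3 to compound 4, 2.0-fold (0.31 log units) apart, within the scatter of two such steps. Among these compounds, the two cores are therefore compatible with one shared step size for this change, but that size is not established, since only one of the two steps clears the scatter, and two pairs give no basis for carrying the change to any other core.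

The compounds shown leave open how a shorter chain such as pentyl or a longer chain such as undecyl would read in this assay, and whether the oxygen-linked and sulfur-linked cores would still track each other there. Going by these compounds, what an amine in place of the oxygen or the sulfur, or a carboxylic acid on the chain, would do to these numbers also stays open.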